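Swapping a urea tail for a piperidine ring

This account rests on a few compounds, and the source may have more. Where it says the series, first, only, none or still open, it means among the compounds named here.

Of the compounds shown here, two with a shared core have been measured in an ADME assay on microsomes from liver (Mus musculus) for metabolic stability, using NADPH, with a stated time of 10 min; a higher number here means that more of the compound is left, a lower number that less of the compound is left. Compound 1, `NCCCCN(C[C@H]1Cc2cccnc2CN1)[C@H]1CCCc2cccnc21`, carries a plain chain on its central amine nitrogen, and in this assay compound 1 gives 69%. Compound 2, `NC(=O)NCCCCN(C[C@H]1Cc2ncccc2CN1)[C@H]1CCCc2cccnc21`, carries a ureidomethyl group at the end of that chain, and in this assay compound 2 gives 32%. Of the two numbers, compound 2 stands lowest, with compound 1 sitting a good distance higher, a gap that lies beyond the usual scatter of this kind of measurement.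

Compound 3, `c1cnc2c(c1)CN[C@@H](CN(CCCC1CCNCC1)[C@H]1CCCc3cccnc31)C2`, has not yet been measured. It differs from compound 2 in one place: piperidin-4-yl in place of ureidomethyl on a saturated chain carbon, three bonds along the chain from an amine nitrogen. Going by the values given here, no measured pair shows this exact change, so its effect can only be guessed. With compound 1 at 69% and compound 2 at 32% as the only anchors, the step from compound 2 to compound 3 is expected to be modest and upward, a number 16 percentage points higher from compound 2 to compound 3 (beyond the scatter), though a step within the scatter would not surprise. Compound 3 is therefore estimated at 48%, expected to fall between 25% and 72%.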

Compound 3, percent of the compound remaining: 69%
Beside the measured number, compound 3's estimate is 21 percentage points below it; measured number inside the range.
By their numbers in this assay, from the lowest: compound 2; then compounds 1 and 3 (each within the scatter of the next).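

Going by these compounds alone, this is the first change at this position that can be read on its own, since the earlier compounds offered no pair differing in one place. In this assay, putting piperidin-4-yl in place of ureidomethyl on a saturated chain carbon, three bonds along the chain from an amine nitrogen, gives a number 37 percentage points higher from compound 2 to compound 3 (beyond the scatter), a large step. The position is therefore sensitive to what sits at the end of the chain: an open group with a carbonyl and two hydrogen-bond donors gives way to a six-membered non-aromatic ring with one nitrogen and one hydrogen-bond donor, and the read-out moves well past the usual scatter.

Why the number moves is not addressed by any accompanying measurement. Within the data shown here, the single step also cannot separate the effect of losing the urea from that of gaining the ring, so a cyclohexyl group, which has the ring but no nitrogen, and an open-chain amine, which has the nitrogen but no ring, would be the informative neighbours, and a carboxylic acid at the same place remains an open case too.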